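The compounds below may be only part of what the source reports. "The series", "measured", "known", "first", "only" and "open" are said of these compounds alone.

Compound 3 `Cc1ccc(-c2nc(SCC#N)c3cc(Cl)ccc3n2)cc1` stands second highest of the three numbers in a functional assay on HeLa cells (Homo sapiens) for antiproliferative activity, read by MTT assay, with a stated time of 48 h (on this read-out higher numbers stand for weaker inhibition and lower numbers for stronger inhibition), where compound 3 gives 3.76 ug/mL. Its nearest neighbour is compound 1 `Cc1ccc(-c2nc(N)c3cc(Cl)ccc3n2)cc1`, which in this assay gives 3.56 ug/mL; the step of a 1.1-fold higher number from compound 1 to compound 3 (0.02 log units; within the scatter) lies within the scatter. Compound 2 `Cc1ccc(-c2nc(NC(=O)c3ccccc3)c3cc(Cl)ccc3n2)cc1` gives 16.2 ug/mL, and the steps of a 4.6-fold higher number from compound 1 to compound 2 (0.66 log units; beyond the scatter) and a 4.3-fold lower number from compound 2 to compound 3 (0.63 log units; beyond the scatter) are both beyond it. Compound 4 `Cc1ccc(-c2nc(SCCO)c3cc(Cl)ccc3n2)cc1` differs from compound 3 by hydroxymethyl in place of cyano on a saturated chain carbon bound to a sulfur. Among the measured compounds shown here, no measured step alters this chain directly; the step from compound 1 to compound 3 bears on it most, showing that a small change at this carbon of the shared core left the number within the scatter, so no step beyond the scatter is expected: a 1.2-fold higher number from compound 3 to compound 4 (0.08 log units; within the scatter). Compound 4 is therefore expected to give 4.5 ug/mL, with a range from 1.8 ug/mL to 11 ug/mL.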

Compound 4, half-maximal inhibitory concentration: 9.25 ug/mL
Estimate against measurement, compound 4: 2.1-fold (0.31 log units) below; low and high end bracket the measured number.
By their numbers in this assay, from the lowest: compounds 1 and 3 (each within the scatter of the next); then compounds 4 and 2 (each within the scatter of the next).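

In this assay the terminal group on the saturated chain carbon bound to a sulfur matters: hydroxymethyl in place of cyano gives a 2.5-fold higher number from compound 3 to compound 4 (0.39 log units; beyond the scatter) on this read-out. The (2-hydroxyethyl)sulfanyl group also separates from amino, with a 2.6-fold higher number from compound 1 to compound 4 (0.41 log units; beyond the scatter) as the step, which (cyanomethyl)sulfanyl did not do. Against benzamido it gives a 1.8-fold lower number from compound 2 to compound 4 (0.24 log units; within the scatter) and so does not separate. No measured evidence accounts for these differences.

The compounds shown leave open how an amine, a carboxylic acid or a longer chain would behave at this carbon.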